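Replacing Acetyl with Nitrophenylsulfonyl on the Amine Nitrogen

The compounds below may be only part of what the source reports. "The series", "measured", "known", "first", "only" and "open" are said of these compounds alone.

Compound 1 `CC(=O)N[C@H]1[C@H]([C@@H](O)[C@H](O)CNC(=O)c2ccc(Cl)cc2)O[C@@](OCc2ccc(Cl)cc2)(C(=O)O)C[C@@H]1O`: 15000 nM
Compound 2 `CC(=O)N[C@H]1[C@H]([C@@H](O)[C@H](O)CNC(=O)c2ccc(Cl)cc2)O[C@@](OCc2cccc(Cl)c2Cl)(C(=O)O)C[C@@H]1O`: 4300 nM
Compound 3 `CC(=O)N[C@H]1[C@H]([C@@H](O)[C@H](O)CNC(=O)c2ccc(Cl)cc2)O[C@@](OCc2cccc(F)c2F)(C(=O)O)C[C@@H]1O`: 2400 nM

The three measured compounds share one core and differ only in the aryl group on a saturated chain carbon bound to an oxygen on a saturated carbon. In an in vitro assay on cells for binding affinity to myelin-associated glycoprotein (Mus musculus), read by surface plasmon resonance (a higher number here means weaker binding, a lower number tighter binding), the spread is modest: a 3.5-fold lower number from compound 1 to compound 2 (0.54 log units; beyond the scatter), a 6.3-fold lower number from compound 1 to compound 3 (0.80 log units; beyond the scatter), while a 1.8-fold lower number from compound 2 to compound 3 (0.25 log units; within the scatter). Compound 3 therefore has the lowest number of the three, but its gap to compound 2 is within the scatter, so the two cannot be ranked against each other.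

Compound 4 `O=C(NC[C@@H](O)[C@H](O)[C@@H]1O[C@@](OCc2cccc(F)c2F)(C(=O)O)C[C@H](O)[C@H]1NS(=O)(=O)c1ccccc1[N+](=O)[O-])c1ccc(Cl)cc1` keeps the aryl group of compound 3 and alters a different part of the molecule: (2-nitrophenyl)sulfonyl in place of acetyl on an amine nitrogen. Among the compounds with values here, none of the measured steps touches this nitrogen; all three concern the aryl group elsewhere, so they give no guide to either direction or size of the change here. The expectation rests on compound 3 alone, with wide uncertainty, and the step of a 1.6-fold lower number from compound 3 to compound 4 (0.20 log units; within the scatter) is an estimate rather than an inference from the data. Compound 4 is expected to give about 1500 nM in this assay, within a range of 250 nM to 9000 nM.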

Compound 4, dissociation constant: 1400 nM
Beside the measured number, compound 4's estimate is 1.1-fold (0.03 log units) above it; the measured number falls inside the stated range.
By their numbers in this assay, from the lowest: compounds 4, 3 and 2 (each within the scatter of the next, the first and the last beyond it); then compound 1.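

In this assay, within the data shown here, the first change at the amine nitrogen gives a 1.7-fold lower number from compound 3 to compound 4 (0.23 log units; within the scatter), so the acetyl and (2-nitrophenyl)sulfonyl compounds cannot be ranked against each other. This shows that, with the 2,3-difluorophenyl group held constant, binding at this nitrogen stays within the scatter even when a group of 3 heavy atoms and no ring gives way to one of 12 heavy atoms carrying a six-membered aromatic ring. The earlier compounds varied only the aryl group elsewhere in the molecule, so they could not show this, and no measurement shown here explains why the two numbers remain so close.

Going by these compounds, this single exchange alters the sulfonyl link, the aromatic ring and the nitro group together, so their separate contributions remain open; a methylsulfonyl or plain phenylsulfonyl group, or a free amine, on the same nitrogen would begin to separate them. On these data alone, it also remains open whether (2-nitrophenyl)sulfonyl behaves in the same way when paired with the 4-chlorophenyl group of compound 1 or the 2,3-dichlorophenyl group of compound 2.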